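Moving a methoxy group on compound 2

The source may hold more compounds than are shown below. What is called first, only, known or untested is meant among the compounds shown, and "the series" means these compounds.

Measured in a functional assay on A549 cells (Homo sapiens) for antiproliferative activity, read by MTT assay, with a stated time of 72 h; a higher number here means a weaker inhibitor, a lower number a stronger inhibitor
Compound 1 `C/C=C/C(=O)Nc1cccc(Oc2nc(Nc3cccc(OC)c3)nc3c2CSCC3)c1` gives 21100 nM
Compound 2 `CC/C=C/C(=O)Nc1cccc(Oc2nc(Nc3cccc(OC)c3)nc3c2CSCC3)c1` gives 17200 nM
Compound 3 `COc1cccc(Nc2nc3c(c(Oc4cccc(NC(=O)/C=C/C(C)C)c4)n2)CSCC3)c1` gives 25300 nM

Compound 2 stands level with the other two, since its steps to both lie within the usual scatter of repeated measurements. No ranking can be read from these three numbers.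

The next structure is compound 4 (`CC/C=C/C(=O)Nc1cccc(Oc2nc(Nc3ccc(OC)cc3)nc3c2CSCC3)c1`), which has the same atoms as compound 2, joined differently (4-methoxyphenyl in place of 3-methoxyphenyl on a nitrogen on an aromatic ring). The change is 4-methoxyphenyl in place of 3-methoxyphenyl on a nitrogen on an aromatic ring.

For the measured compounds named here, no measured step tests this change. All three steps alter a chain, not the methoxyphenyl group (a 1.2-fold lower number from compound 1 to compound 2 (0.09 log units; within the scatter)) and (a 1.2-fold higher number from compound 1 to compound 3 (0.08 log units; within the scatter)) and (a 1.5-fold higher number from compound 2 to compound 3 (0.17 log units; within the scatter)). Going by the values given here, each is within the scatter, so they show only that these chain changes left the number in this assay essentially unmoved. They give no direction for the new change, so the expectation is no step beyond the scatter, held with a wide margin.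

The expected step is small (a 1.0-fold higher number from compound 2 to compound 4 (0.02 log units; within the scatter)).

Compound 4 is therefore estimated at 18000 nM (estimated range 8000 nM to 40000 nM).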

Compound 4, half-maximal inhibitory concentration: 20100 nM
Compound 4: middle estimate off by 1.1-fold (0.05 log units), on the low side, and the stated range covers the measured number.
By their numbers in this assay, from the lowest: compounds 2, 4, 1 and 3 (each within the scatter of the next).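

This is the first step shown that touches the methoxyphenyl group rather than the chain on the amide. In this assay, putting 4-methoxyphenyl in place of 3-methoxyphenyl on the nitrogen gives a 1.2-fold higher number from compound 2 to compound 4 (0.07 log units; within the scatter), so moving the methoxy group on this ring leaves the number essentially unmoved, and compound 2 and compound 4 cannot be ranked against each other. No measurement is at hand that could explain this result.

Every compound shown carries a methoxy group on this ring, so it remains open whether the number would stay as flat with an amine, a carboxylic acid or a longer chain such as butoxy there, or with no group on the ring at all. For the compounds shown here, the move has also been seen only with the chain of compound 2, so whether it would behave the same way with the shorter chain of compound 1 or the isopropyl-bearing chain of compound 3 also stays unanswered.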